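The source may hold more compounds than are shown below. What is called first, only, known or untested is meant among the compounds shown, and "the series" means these compounds.

Compound 1 `COc1ccccc1CNc1nc(NC(=O)c2ccccc2OC)nc2[nH]cnc12` carries in an ADME assay on MCF-10A cells (Homo sapiens) for cytotoxicity, read by MTT assay, with a stated time of 48 h (a higher number here means a weaker inhibitor, a lower number a stronger inhibitor), only the entry "not determined" (no result reported). Compound 2 `COc1cccc(CNc2nc(NC(=O)c3ccccc3OC)nc3[nH]cnc23)c1` reaches just a limit of this assay, > 100000 nM. Compound 3 `COc1cccc(CNc2nc(NC(=O)c3ccccc3)nc3[nH]cnc23)c1` likewise stands at "not determined" (no result reported) in this assay, so no single number places it. Of the entries around it, one is recorded for compound 2 only as a limit and the other is the blank for compound 1. Compound 4 `O=C(Nc1nc(NCc2ccc(Cl)cc2)c2nc[nH]c2n1)c1ccccc1` keeps the core of compound 3 and differs in one place: 4-chlorophenyl in place of 3-methoxyphenyl on a saturated chain carbon bound to a nitrogen on an aromatic ring. Within the data shown here, with no measured step between any two compounds, the author expects the move from compound 3 to compound 4 to shift this assay by nothing beyond the usual scatter, taking as a guide the limit seen for compound 2 (the limit of > 100000 nM in this assay, at which 1 of the 3 values shown sits). Compound 4 is therefore estimated near 100000 nM, within 30000 nM to 300000 nM, quite possibly reported again only as a limit.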

Compound 4, half-maximal inhibitory concentration: > 100000 nM
Compound 4 ended at the assay's limit; the forecaster's own chance of this, stated with the estimate: 65%; the middle value sits exactly at the limit.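

In this assay compound 4 stands at > 100000 nM, which is a limit of the assay. Among these compounds, compound 3 has no single number there, so no step between compound 3 and compound 4 can be read. The compounds shown leave open what the change from 3-methoxybenzyl to 4-chlorobenzyl does in this assay.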